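The source may report more compounds than this note shows. Statements on the series, on what has been measured and on what is new or still open speak of the compounds shown alone.

Working notes on the quaternary-ammonium series.

Compound 1 `Cc1cc(-n2cc(C(=O)Nc3cc(F)cc(F)c3)c(=O)c3ccc(N(C)C)nc32)ccc1OCCCCCCC[N+]1(C)CCCC1` carries a five-membered non-aromatic ring with one hetero atom on the chain end; in an assay on LX2 cells for inhibition of COL1A1 promoter (Homo sapiens), read by a luciferase reporter, with a stated time of 24 h, tested at 50 uM (on this read-out higher numbers stand for a stronger effect at the one concentration tested and lower numbers for a weaker effect), compound 1 gives 35.9%. Compound 2 `Cc1cc(-n2cc(C(=O)Nc3cc(F)cc(F)c3)c(=O)c3ccc(N(C)C)nc32)ccc1OCCCCCCC[N+]1(C)CCCCC1` has the six-membered ring in its place, and in this assay compound 2 gives 54.4%, a change of a number 18.5 percentage points higher from compound 1 to compound 2 (beyond the scatter). Compound 3 `CC[N+]1(CCCCCCCOc2ccc(-n3cc(C(=O)Nc4cc(F)cc(F)c4)c(=O)c4ccc(N(C)C)nc43)cc2C)CCCCC1` adds methyl on the saturated chain carbon bound to the ring amine nitrogen; in this assay compound 3 gives 53.4%. The step of a number 17.5 percentage points higher from compound 1 to compound 3 (beyond the scatter) again lies beyond the scatter, whereas a number 1 percentage points lower from compound 2 to compound 3 (within the scatter) does not. Compound 3 therefore sits second of the three numbers, with compound 2 alongside it and compound 1 clearly lower.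

Compound 4 `CC[N+]1(CCCCCCCOc2ccc(-n3cc(C(=O)Nc4cc(F)cc(F)c4)c(=O)c4ccc(N(C)C)nc43)cc2C)CCCC1` is reached from compound 3 by a group of 7 heavy atoms (6 carbon, 1 nitrogen; one five-membered non-aromatic ring with 1 hetero atom) in place of a group of 8 heavy atoms (7 carbon, 1 nitrogen; one six-membered non-aromatic ring with 1 hetero atom), on a saturated chain carbon, seven bonds along the chain from an oxygen on an aromatic ring. This reverses the ring change seen in the steps from compound 1 to compound 2 and from compound 1 to compound 3, both of which were modest gains beyond the scatter, while the methyl difference in the step from compound 2 to compound 3 was within the scatter. The expected step in this assay is therefore a modest drop, a number 16.4 percentage points lower from compound 3 to compound 4 (beyond the scatter). For compound 4 the estimated value in this assay is 37%, within 24% to 50%.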

Compound 4, a percentage reported as inhibition, at one concentration (the size of the read-out at that concentration, not a potency): 82.5%
The estimate for compound 4 lay 45.5 percentage points below the measured number, outside the stated range (above it).
By their numbers in this assay, from the lowest: compound 1; then compounds 3 and 2 (each within the scatter of the next); then compound 4.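

Working notes, continued. In this assay, the effect of ring size is not fixed: with the added methyl present, the five-membered ring gives a number 29.1 percentage points higher from compound 3 to compound 4 (beyond the scatter), whereas without that methyl the six-membered ring gave a number 18.5 percentage points higher from compound 1 to compound 2 (beyond the scatter). Compound 4 also stands clear of the other methyl-free and methyl-bearing six-membered comparison, with a number 28.1 percentage points higher from compound 2 to compound 4 (beyond the scatter), and its steps to all three other compounds lie beyond the scatter, which gives it the highest number in this set. The earlier compounds suggested that the added methyl made no difference, but on the five-membered ring it gives a number 46.6 percentage points higher from compound 1 to compound 4 (beyond the scatter), so its effect at this position depends on the ring that carries it: the same change on two cores in this assay, a number 1 percentage points lower (within the scatter) from compound 2 to compound 3 and a number 46.6 percentage points higher (beyond the scatter) from compound 1 to compound 4, 47.6 percentage points apart, beyond the scatter of two such steps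

The compounds shown leave open whether this dependence on ring size extends to a seven-membered azepane ring, a morpholine ring or a propyl group on the ring nitrogen. On these data alone, it is also open whether the same order holds with a shorter chain between the aromatic oxygen and the ring, and at concentrations other than the single one tested.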